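Swapping a nitro for a chloro on the aromatic ring

A few compounds are considered here, and "the series" means these few. Any claim that something is new, unique, unknown or untested is made for them only; others in the source may bear on it.

Measured so far:
- compound 1, `O=C1CSC(c2ccccc2[N+](=O)[O-])N1CCN1CCCCC1`, 24%
- compound 2, `COc1cccc(C2SCC(=O)N2CCN2CCCCC2)c1`, 11%

Of the compounds shown here, two share a core and have been tested in an ADME assay on Vero cells (Chlorocebus sabaeus) for cytotoxicity, read by neutral red uptake, tested at 1575 ug/mL; a higher number here means a weaker effect of the compound at the concentration tested, a lower number a stronger effect. Compound 1 gives 24% in this assay, and compound 2 gives 11%. Compound 1 thus stands highest of the two numbers, and its nearest neighbour, compound 2, lies lower by a gap that is beyond the usual scatter. Both numbers are low, so both compounds act strongly on the cells at the concentration used.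

The next compound, compound 3, `O=C1CSC(c2ccccc2Cl)N1CCN1CCCCC1`, differs from compound 1 in one place: chloro in place of nitro on an aromatic carbon. Among the measured compounds shown here, no step between two measured compounds mirrors this change, so there is no direct guide to its size. Since compound 1 and compound 2 both land low in this assay, compound 3 is expected to stay in that low region, with a step from compound 1 of a number 6 percentage points lower from compound 1 to compound 3 (within the scatter) that may fall within the scatter or slightly below it. The estimate for compound 3 is 18%, with a range from 5% to 35%.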

Compound 3, a percentage reported as activity, at one concentration (the size of the read-out at that concentration, not a potency): 16%
Beside the measured number, compound 3's estimate is 2 percentage points above it; low and high end bracket the measured number.
By their numbers in this assay, from the lowest: compounds 2, 3 and 1 (each within the scatter of the next, the first and the last beyond it).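

In this assay, among the compounds shown here, the change of nitro to chloro gives the first direct reading at this position, an aromatic carbon ortho to a large group: a number 8 percentage points lower from compound 1 to compound 3 (within the scatter). Chloro has 1 heavy atom and no hydrogen-bond acceptors, whereas nitro has 3 heavy atoms and 2 hydrogen-bond acceptors, yet this exchange on the shared core gives no difference that can be told apart from the variation between repeated measurements. The information at hand offers no measured property that could account for this result.

These compounds leave open whether any group placed on this aromatic carbon would give a clear step, for example an amine or a carboxylic acid, since nitro and chloro are the only two compared here. They also leave open whether the same exchange would read alike on another carbon of the aromatic ring, and whether a reading at this single test concentration would hold at others.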